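A few compounds are considered here, and "the series" means these few. Any claim that something is new, unique, unknown or untested is made for them only; others in the source may bear on it.

Compound 1 `Fc1ccc(CSc2nnc(-c3cnccn3)o2)c(F)c1` gives 26700 nM
Compound 2 `c1ccc(CSc2nnc(-c3cnccn3)s2)cc1` gives 34400 nM
Compound 3 `Clc1ccccc1CSc1nnc(-c2cnccn2)n1-c1ccccc1` gives > 50000 nM (a limit, not a number)

These three readings all come from a functional assay on HeLa cells (Homo sapiens) for antiproliferative activity, read by MTT assay, with a stated time of 48 h (a higher number here means a weaker inhibitor, a lower number a stronger inhibitor), and they are few. The values of compound 1 and compound 2 lie within the usual scatter of each other, so neither can be called the stronger. Compound 3 gives > 50000 nM as its entry, and that is a limit of the assay and not a number.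

Compound 4 `Fc1cccc(F)c1CSc1nnc(-c2cnccn2)n1-c1ccccc1` keeps the rest of compound 3 and carries 2,6-difluorophenyl in place of 2-chlorophenyl on a saturated chain carbon bound to a sulfur. Counted out, the change reads 2,6-difluorophenyl in place of 2-chlorophenyl on a saturated chain carbon bound to a sulfur and nothing else in the structure differs.

Within the data shown here, no two measured compounds here differ in one place only, so no measured step shows what a swap of this kind does. In this assay the expectation is therefore for no shift beyond the usual scatter, in either direction. That expectation starts from compound 3 and its > 50000 nM entry, which is again a limit. The estimated change is an at least 1.1-fold lower number from compound 3 to compound 4 (0.04 log units; that floor lies within the scatter) and it is expected to stay small. For compound 4 the estimated value is 45000 nM, with an expected range from 22000 nM to 80000 nM.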

Compound 4, half-maximal inhibitory concentration: > 50000 nM
Compound 4 ended at the assay's limit (the forecaster's own chance of this, stated with the estimate: 55%); at least 1.1-fold (0.04 log units) between middle value and limit.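

Neither compound 3 nor compound 4 gives a number, so putting 2,6-difluorophenyl in place of 2-chlorophenyl yields no step that can be read, as both entries stand at the same limit: the limit of > 50000 nM in this assay, at which 2 of the 4 values shown sit.

The compounds shown leave open whether this swap shifts antiproliferative activity in either direction.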